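This account rests on a few compounds, and the source may have more. Where it says the series, first, only, none or still open, it means among the compounds named here.

Compound 1 `CCC(=O)NCC(=O)N(C)c1ccc(Cl)cc1C(=O)c1ccccc1Cl`: 1.4 mg/kg
Compound 2 `CC(=O)NCC(=O)Nc1ccc(Cl)cc1C(=O)c1ccccc1Cl`: > 100 mg/kg (a limit of the assay, not a number)

In a functional assay on the whole organism for antagonist activity, with Mus musculus as the target (on this read-out lower numbers stand for an effect already at smaller amounts and higher numbers for an effect only at larger amounts of compound), compound 1 gives 1.4 mg/kg. Going by the values given here, this is the only true number so far. Compound 2 reached only a limit, > 100 mg/kg. The two measured compounds differ in more than one place, so their values alone do not show what any single group contributes.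

Compound 3 `CN(C)CC(=O)NCC(=O)N(C)c1ccc(Cl)cc1C(=O)c1ccccc1Cl` has not yet been measured. It keeps the core of compound 1 but carries dimethylamino in place of methyl on a saturated chain carbon bound to a carbonyl carbon. Among the compounds with values here, no measured pair isolates a change of this kind, so any forecast is uncertain and the range must stay wide. In this assay the expected step of a 3.6-fold higher number from compound 1 to compound 3 (0.55 log units; beyond the scatter) is a moderate one toward larger doses, somewhat beyond the usual scatter. For compound 3 the estimated value is 5 mg/kg, with an expected range from 1.2 mg/kg to 30 mg/kg.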

Compound 3, dose for half-maximal effect: 2.6 mg/kg
Estimate against measurement, compound 3: 1.9-fold (0.28 log units) above, within the range that was stated.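

In this assay, going by these compounds alone, the exchange of methyl for dimethylamino on a saturated chain carbon bound to a carbonyl carbon gives a 1.9-fold higher number from compound 1 to compound 3 (0.27 log units; within the scatter), the first step that can be read at a single place. The position therefore accepts dimethylamino, with 3 heavy atoms in place of 1 and one more hydrogen-bond acceptor, without a shift beyond the scatter, and compound 1 and compound 3 stand as equals on this read-out. Nothing measured on these compounds accounts for the size of this step.

Compound 2 gives > 100 mg/kg, which is a limit of the assay and not a number, and since it differs from compound 1 in more than one place, the contribution of each of those differences remains unassigned. Also open, going by these compounds, is how far this position tolerates other groups in place of dimethylamino, such as a cyclic amine like piperidine, a carboxylic acid or a longer chain, since a single step cannot show whether the tolerance seen here extends to them.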